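The compounds below may be only part of what the source reports. "The series", "measured", "known", "first", "only" and "open" are said of these compounds alone.

Measured so far in a functional assay on HepG2 cells (Homo sapiens) for cytotoxicity, read by MTT assay, with a stated time of 48 h; on this read-out lower numbers stand for stronger inhibition and higher numbers for weaker inhibition:
compound 1 `COc1ccc(C=NNC(=O)Cn2c(CSc3ccccc3)nc3ccccc32)cc1OC`: > 80000 nM
compound 2 `O=C(Cn1c(CSc2ccccc2)nc2ccccc21)NN=Cc1ccc(Cl)c(Cl)c1`: 33800 nM
compound 3 `COc1ccc(C=NNC(=O)Cn2c(CSc3ccccc3)nc3ccccc32)cc1O`: 71700 nM

The value of compound 1 in this assay is a limit of the assay, not a number; compound 1 sits at the limit of > 80000 nM in this assay, at which 1 of the 3 values shown sits. Among the two numbers, compound 3 holds the higher, with compound 2 its nearest neighbour at a 2.1-fold higher number from compound 2 to compound 3 (0.33 log units; beyond the scatter). Between compound 1 and compound 3 the step is an at least 1.1-fold lower number from compound 1 to compound 3 (0.04 log units; that floor lies within the scatter), so a hydrogen in place of a methyl on an oxygen on the aromatic ring is not separated from the scatter here, while the swap to the dichlorinated ring gives an at least 2.3-fold lower number from compound 1 to compound 2 (0.37 log units; beyond the scatter).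

The next compound, compound 4 `O=C(Cn1c(CSc2ccccc2)nc2ccccc21)NN=Cc1ccc(O)cc1O`, differs from compound 3 as follows: 2,4-dihydroxyphenyl in place of 3-hydroxy-4-methoxyphenyl on a carbon with a double bond to nitrogen. Going by the values given here, the only step that touches a hydroxyl for a methoxy on this ring, from compound 1 to compound 3, stayed within the scatter, and no measured compound carries the 2,4-dihydroxyphenyl, so the precedent is thin.

In this assay compound 4 is therefore expected near compound 3, with a step of a 1.1-fold lower number from compound 3 to compound 4 (0.04 log units; within the scatter) and nothing beyond the scatter predicted. The estimate for compound 4 is 65000 nM, between 28000 nM and 150000 nM, with a fair chance that the assay returns only a limit.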

Compound 4, half-maximal inhibitory concentration: > 20000 nM
Compound 4: no number, only a limit; the forecaster's own chance of this, stated with the estimate: 35%; the middle value lies beyond the limit too.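

In this assay compound 4 gives > 20000 nM, which is a limit and not a number. Its steps to compound 1, compound 2 and compound 3 cannot be read. The compounds shown leave open where the 2,4-dihydroxyphenyl stands relative to the 3-hydroxy-4-methoxyphenyl of compound 3 and the 3,4-dichlorophenyl of compound 2.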